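A few compounds are considered here, and "the series" means these few. Any claim that something is new, unique, unknown or untested is made for them only; others in the source may bear on it.

In a functional assay on A549 cells (Homo sapiens) for antiproliferative activity, read by sulforhodamine B assay, with a stated time of 72 h (a higher number here means a weaker inhibitor, a lower number a stronger inhibitor), compound 1 `COc1cc2occ(-c3csc4ccccc34)c(=O)c2c(OC)c1OC` gives 640 nM and so holds the lowest number of the three measured compounds. Compound 2 `COc1cc2occ(-c3csc4ccccc34)c(=O)c2c(OC)c1O` shows > 10000 nM as a limit. Compound 3 `CCOc1c(OC)cc2occ(-c3csc4ccccc34)c(=O)c2c1OC` gives 4800 nM as a measured number. Compound 4 `COc1cc2occ(-c3csc4ccccc34)c(=O)c2cc1OC` differs from compound 1 by hydrogen in place of methoxy on an aromatic carbon. Going by the values given here, no measured step removes a methoxy group outright, but two alter another methoxy group of compound 1, and both raise the number, with an at least 15-fold higher number from compound 1 to compound 2 (1.19 log units; beyond the scatter) as a large step and a 7.5-fold higher number from compound 1 to compound 3 (0.88 log units; beyond the scatter) as a modest one. A rise of modest size is therefore expected for compound 4 in this assay. Compound 4 is estimated at 4000 nM (expected range 1000 nM to 15000 nM). The estimate implies this expected step (a 6.3-fold higher number from compound 1 to compound 4 (0.80 log units; beyond the scatter)).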

Compound 4, half-maximal inhibitory concentration: > 10000 nM
Compound 4 was reported as a limit; the forecaster's own chance of this, stated with the estimate: 25%; middle value at least 2.5-fold (0.39 log units) from the limit.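

In this assay, hydrogen in place of methoxy on this aromatic carbon gives an at least 15-fold higher number from compound 1 to compound 4 (1.19 log units; beyond the scatter). This shows that outright loss of a methoxy group, here a different one from that altered in compound 2 and compound 3, also raises the number well beyond the scatter. The value of compound 4, > 10000 nM, is a limit and not a number, so the step gives only a lower bound on the change: the limit of > 10000 nM in this assay, at which 2 of the 4 values shown sit.

Going by these compounds, it remains open whether an ethoxy group or an amine on this carbon would keep the number near that of compound 1. On these data alone, the effect of removing the remaining methoxy group also stays open.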